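This account rests on a few compounds, and the source may have more. Where it says the series, first, only, none or still open, it means among the compounds named here.

Of the compounds shown here, three built on the same core have been measured in a physicochemical assay for solubility; on this read-out higher numbers stand for higher solubility and lower numbers for lower solubility. Compound 1 `O=C1OCCN1c1cc(C(F)(F)F)ccc1[C@H]1CCOc2cc(S(=O)(=O)Nc3nccs3)ccc21` gives 295000 nM, the highest of the three numbers. Compound 3 `Cn1nccc1-c1cc(C(F)(F)F)ccc1[C@@H]1CCOc2cc(S(=O)(=O)Nc3nccs3)ccc21` gives 65000 nM, a lower number that lies beyond the usual scatter of the measurement, and compound 2 `Cn1nccc1-c1cc(C(F)(F)F)ccc1[C@H]1CCOc2cc(S(=O)(=O)Nc3cccc(F)n3)ccc21` gives 27000 nM, the lowest of the set. Compound 1 thus stands at the top in this assay, with compound 3 nearest to it and compound 2 furthest away.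

Compound 4 `O=S(=O)(Nc1nccs1)c1ccc2c(c1)OCC[C@@H]2c1ccc(C(F)(F)F)cc1-n1ccnn1` has not yet been measured. It differs from compound 1 in one place: 1H-1,2,3-triazol-1-yl in place of 2-oxo-1,3-oxazolidin-3-yl on an aromatic carbon. Among the compounds with values here, no pair of measured compounds that differ in a single place is available to calibrate this change, so any expectation rests on the spread of the three values alone. The comparison of compound 1 at 295000 nM with compound 3 at 65000 nM suggests that a departure from compound 1 tends to lower the number. A moderate downward step is expected a 2.5-fold lower number from compound 1 to compound 4 (0.39 log units; beyond the scatter), probably just beyond the scatter. Compound 4 is therefore estimated at 120000 nM, within a range from 45000 nM to 290000 nM.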

Compound 4, solubility: 171000 nM
For compound 4 the middle estimate is 1.4-fold (0.15 log units) below the measured one, within the range that was stated.
By their numbers in this assay, from the lowest: compound 2; then compound 3; then compounds 4 and 1 (each within the scatter of the next).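

In this assay, within the data shown here, replacing 2-oxo-1,3-oxazolidin-3-yl with 1H-1,2,3-triazol-1-yl on the aromatic carbon ortho to a large group gives a 1.7-fold lower number from compound 1 to compound 4 (0.24 log units; within the scatter) as the first step in this set that can be read at a single place. At this position, then, a five-membered aromatic ring with 3 hetero atoms can stand in for a five-membered non-aromatic ring with 2 hetero atoms without a difference that can be told from the scatter. Nothing at hand gives a reason for this result.

The compounds shown leave open whether an amine or a carboxylic acid on this aromatic carbon would stay within the scatter of compound 1 or move beyond it. They also leave open whether the same exchange would give a similar step with a different group on the sulfonamide nitrogen.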